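This account rests on a few compounds, and the source may have more. Where it says the series, first, only, none or still open, it means among the compounds named here.

Measured compounds:
compound 1 `COc1cc(Cl)cc(-c2nn(-c3cccc(NC(=O)Nc4cccc(C(F)(F)F)c4)c3)cc2-c2ccncc2)c1`: -7.87%
compound 2 `COc1cc(Cl)cc(-c2nn(-c3cccc(NC(=O)Nc4ccc(Cl)c(C(F)(F)F)c4)c3)cc2-c2ccncc2)c1`: -7.48%
compound 3 `COc1cc(Cl)cc(-c2nn(-c3cccc(NC(=O)c4cc(C(F)(F)F)cc(C(F)(F)F)c4)c3)cc2-c2ccncc2)c1`: 42.1%

In a functional assay on SF-295 cells (Homo sapiens) for inhibition, read by sulforhodamine B assay, with a stated time of 48 h, tested at 10 uM (a higher number here means a weaker effect of the compound at the concentration tested, a lower number a stronger effect), compound 1 gives -7.87%, the lowest of the three numbers. Among the compounds with values here, its nearest neighbour is compound 2, and the step of a number 0.4 percentage points higher from compound 1 to compound 2 (within the scatter) is the only single-point change measured here. Compound 3 stands furthest away, and the gap between the values of compound 1 and compound 3 is beyond the scatter, though the two structures differ in more than one place.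

Compound 4 `COc1cc(Cl)cc(-c2nn(-c3cccc(NC(=O)c4cccc(C(F)(F)F)c4)c3)cc2-c2ccncc2)c1` is not yet measured. It differs from compound 1 by 3-(trifluoromethyl)phenyl in place of (3-(trifluoromethyl)phenyl)amino on a carbonyl carbon. Within the data shown here, no measured step covers this change alone; only the two values of compound 1 and compound 3 point the same way, both toward a weaker effect. The step of a number 29.9 percentage points higher from compound 1 to compound 4 (beyond the scatter) is therefore expected to be upward, but less sure than a measured step. Compound 4 is expected to give about 22%, in the range -8% to 50%.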

Compound 4, a percentage reported as activity, at one concentration (the size of the read-out at that concentration, not a potency): 37.9%
Beside the measured number, compound 4's estimate is 15.9 percentage points below it; the measured number falls inside the stated range.
By their numbers in this assay, from the lowest: compounds 1 and 2 (each within the scatter of the next); then compounds 4 and 3 (each within the scatter of the next).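

In this assay, 3-(trifluoromethyl)phenyl in place of (3-(trifluoromethyl)phenyl)amino on the carbonyl carbon weakens the effect by a large margin, with a number 45.8 percentage points higher from compound 1 to compound 4 (beyond the scatter), and the chlorinated pair agrees, with a number 45.4 percentage points higher from compound 2 to compound 4 (beyond the scatter), although that step also removes the chloro. The second trifluoromethyl carries no weight beyond the scatter, with a number 4.2 percentage points lower from compound 3 to compound 4 (within the scatter). Nothing at hand explains the size of the change. As far as these compounds go, it remains open whether a sulfonamide or a carbamate at this place would give numbers like those of compound 1 or compound 4.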